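Efficacy notes: aryl group on the piperazine nitrogen

The compounds below may be only part of what the source reports. "The series", "measured", "known", "first", "only" and "open" are said of these compounds alone.

Measured compounds:
- compound 1, `CCCO/N=C(\CCN1CCN(c2ccccn2)CC1)c1ccccc1`: 64%
- compound 2, `CCO/N=C(\CCN1CCN(c2cccc(OC)c2)CC1)c1ccccc1`: 30%
- compound 3, `CO/N=C(/CCN1CCN(c2ccccc2OC(C)C)CC1)c1ccc(F)cc1`: 59%

All three were run in a functional assay on HEK293 cells with D(4) dopamine receptor (Homo sapiens) as the target, read by FLIPR; a lower number here means a smaller maximal response, a higher number a larger maximal response. In this assay compound 2 gives 30%, the lowest of the three numbers. Compound 3 stands nearest to it, yet already beyond the scatter above it; compound 1 stands furthest above it, also beyond the scatter. Within the data shown here, no pair of these three differs in only one place, so no single step can be isolated from the measured set.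

Compound 4, `CCO/N=C(\CCN1CCN(c2ncccn2)CC1)c1ccccc1`, remains to be measured in this assay. It differs from compound 2 in one place: pyrimidin-2-yl in place of 3-methoxyphenyl on an amine nitrogen in a ring. The aryl group that enters is a six-membered aromatic ring with 2 hetero atoms, closer in kind to the group carried by compound 1 than to the 3-methoxyphenyl of compound 2.

For compound 4 an efficacy of 50% is expected, in the range 30% to 70%. This expectation means a step of a number 20 percentage points higher from compound 2 to compound 4 (beyond the scatter), upward and beyond the scatter, because compound 1 gives 64%.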

Compound 4, largest response reached (reported as efficacy), in percent of the reference or control that the assay uses: 26%
Beside the measured number, compound 4's estimate is 24 percentage points above it, outside the stated range (below it).
By their numbers in this assay, from the lowest: compounds 4 and 2 (each within the scatter of the next); then compounds 3 and 1 (each within the scatter of the next).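

In this assay, among these compounds, pyrimidin-2-yl in place of 3-methoxyphenyl on an amine nitrogen in a ring gives a number 4 percentage points lower from compound 2 to compound 4 (within the scatter), the only step in the set that can be read in one place. With the rest of the structure held constant, these two aryl groups therefore cannot be told apart by maximal response in this assay, although they differ in ring hetero atoms and in heavy-atom count. No measurement shown here bears on the reason for this result.

Open, as far as these compounds go, is whether an unsubstituted phenyl, a cyclohexyl or an acetyl group on the same nitrogen, with the rest of compound 2 unchanged, would also stay within the scatter. Also open, from the compounds shown here alone, is whether pyrimidin-2-yl and 3-methoxyphenyl read alike on the cores of compound 1 and compound 3.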